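A few compounds are considered here, and "the series" means these few. Any claim that something is new, unique, unknown or untested is made for them only; others in the source may bear on it.

Values in an assay on membranes from CHO cells for displacement of a labelled ligand from adenosine receptor A1 (Homo sapiens), read by scintillation counting, with a stated time of 60 min, tested at 1 uM; a lower number here means less inhibition, a higher number more inhibition at the concentration tested (going by the name of the read-out):

Compound 1 `CCCOC(=O)C1=C(C)NC(=S)NC1c1ccco1`: 1%
Compound 2 `CCCOC(=O)C1=C(C)NC(=S)NC1c1ccoc1`: 4%
Compound 3 `CCSC(=O)C1=C(C)NC(=O)NC1c1ccco1`: 6%

All three measured compounds show only small inhibition in this assay. Compound 1 and compound 2 differ by one change, (furan-3-yl in place of furan-2-yl on a saturated ring carbon), and the step that came with it, a number 3 percentage points higher from compound 1 to compound 2 (within the scatter), is small. The difference between the core of compound 1 and the core of compound 3 is not broken down here.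

Compound 4 `CCSC(=O)C1=C(C)NC(=O)NC1c1ccoc1` is not yet measured. It differs from compound 3 by furan-3-yl in place of furan-2-yl on a saturated ring carbon. This is the same kind of change as that from compound 1 to compound 2, though the surroundings differ: in compound 3 the ring atom beside the changed carbon bears a (ethylsulfanyl)carbonyl group, while in compound 1 it bears a propoxycarbonyl group.

Because the earlier step of a number 3 percentage points higher from compound 1 to compound 2 (within the scatter) stayed within the scatter, compound 4 is expected to move only by a number 2 percentage points higher from compound 3 to compound 4 (within the scatter). For compound 4 the estimated value in this assay is 8%, expected to fall between 0% and 18%.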

Compound 4, a percentage reported as inhibition, at one concentration (the size of the read-out at that concentration, not a potency): 3%
For compound 4 the middle estimate is 5 percentage points above the measured one; low and high end bracket the measured number.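

In this assay, putting furan-3-yl in place of furan-2-yl on the core of compound 3 gives a number 3 percentage points lower from compound 3 to compound 4 (within the scatter). Set beside the earlier case, the change shows no difference between the two cores: the same change on two cores in this assay, a number 3 percentage points higher (within the scatter) from compound 1 to compound 2 and a number 3 percentage points lower (within the scatter) from compound 3 to compound 4, 6 percentage points apart, within the scatter of two such steps. Among these compounds, this shows only that the swap brings no sizeable inhibition on either core at the concentration tested; it does not show that the step would stay this small on a core with strong inhibition.

The compounds shown leave open whether a group other than a furan ring on that saturated ring carbon, such as a phenyl ring or an amine-bearing chain, would give more inhibition. They also leave open what a carboxylic acid would do in place of the propoxycarbonyl group.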